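A benzofuran for a thiophene on two related cores

The source may hold more compounds than are shown below. What is called first, only, known or untested is meant among the compounds shown, and "the series" means these compounds.

Compound 1 `O=c1[nH]cnc2c1c(-c1cccs1)cn2[C@@H]1O[C@H](CO)[C@@H](O)[C@H]1O` gives > 20000 nM in a functional assay on K562 cells (Homo sapiens), read by MTT assay, with a stated time of 72 h (on this read-out higher numbers stand for weaker inhibition and lower numbers for stronger inhibition), a limit of the assay rather than a number.
Compound 2 `O=c1[nH]cnc2c1c(-c1cc3ccccc3o1)cn2[C@@H]1O[C@H](CO)[C@@H](O)[C@H]1O` gives > 20000 nM in this assay, again a limit.
Compound 3 `CN(C)c1ncnc2c1c(-c1cccs1)cn2[C@@H]1O[C@H](CO)[C@@H](O)[C@H]1O` gives > 20000 nM in this assay, also a limit.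

Within the data shown here, the one change made within the measured set is 1-benzofuran-2-yl in place of thiophen-2-yl on an aromatic carbon, and its step that the two limits leave unreadable from compound 1 to compound 2 cannot be sized, since both ends sit at the same limit. Compound 3 carries a different core from compound 1; the difference between the two cores is not broken down here. Compound 4 `CN(C)c1ncnc2c1c(-c1cc3ccccc3o1)cn2[C@@H]1O[C@H](CO)[C@@H](O)[C@H]1O` has not yet been measured in this assay. Among the measured compounds shown here, it is reached by 1-benzofuran-2-yl in place of thiophen-2-yl on an aromatic carbon, and its place is described in the same words as before, so this is the same change as the one from compound 1 to compound 2, now on the core of compound 3.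

What the measured values show is summed up by the limit of > 20000 nM in this assay, at which 3 of the 3 values shown sit: every reading so far is a limit, and the earlier instance of this change did not move the reading off it. Resting on a step that the two limits leave unreadable from compound 1 to compound 2 and on (the limit of > 20000 nM in this assay, at which 3 of the 3 values shown sit), compound 4 is expected to give 30000 nM, most likely reported again as a limit. The step expected is a step that the limit leaves unreadable from compound 3 to compound 4, with wide room on either side since no numbered value anchors it.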

Compound 4, half-maximal inhibitory concentration: > 20000 nM
Compound 4: only a limit was reported (the forecaster's own chance of this, stated with the estimate: 85%); the middle value does not contradict the limit.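

In this assay compound 4 gives > 20000 nM, a limit of the assay. Among these compounds, the step from compound 3 to compound 4 therefore cannot be read, any more than the one from compound 1 to compound 2. The compounds shown leave open whether 1-benzofuran-2-yl in place of thiophen-2-yl changes inhibition on either core, as every reading rests on one shared limit: the limit of > 20000 nM in this assay, at which 4 of the 4 values shown sit.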